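This account rests on a few compounds, and the source may have more. Where it says the series, first, only, none or still open, it means among the compounds named here.

Compound 2, with the structure `CCOC(=O)C1=C(Nc2ccccc2)S/C(=C\c2cc3cccnc3[nH]2)C1=O`, was tested in a functional assay on MCF7 cells (Homo sapiens) for inhibition, read by MTT assay, with a stated time of 72 h, tested at 10 uM (on this read-out higher numbers stand for more inhibition at the one concentration tested (going by the name of the read-out) and lower numbers for less inhibition), and gives 18.2%. Among the compounds with values here, the only other compound measured so far, compound 1 with the structure `CCOC(=O)C1=C(Nc2ccccc2)S/C(=C\c2ccc(Br)c(O)c2)C1=O`, gives 16.4% in this assay, so the two values sit side by side and the step of a number 1.8 percentage points higher from compound 1 to compound 2 (within the scatter) says nothing about a real difference between them.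

Compound 3, with the structure `CCOC(=O)C1=C(Nc2ccccc2)S/C(=C\c2cc3ncccc3[nH]2)C1=O`, has not yet been measured. It is built from the same atoms as compound 2, joined differently: the change is a group of 9 heavy atoms (7 carbon, 2 nitrogen; one five-membered aromatic ring with 1 hetero atom, one six-membered aromatic ring with 1 hetero atom) in place of a group of 9 heavy atoms (7 carbon, 2 nitrogen; one five-membered aromatic ring with 1 hetero atom, one six-membered aromatic ring with 1 hetero atom), on a double-bonded chain carbon bound to a double-bonded ring carbon.

Within the data shown here, only one measured step bears on this change, and only loosely. From compound 1 to compound 2 the whole group at this place was swapped for a different one, and even that gave a number 1.8 percentage points higher from compound 1 to compound 2 (within the scatter), within the scatter. Rearranging the same atoms within the group, as in compound 3, is a smaller change, and nothing seen so far points to a step beyond the scatter in either direction.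

The expectation for compound 3 is therefore a step of a number 0.2 percentage points lower from compound 2 to compound 3 (within the scatter), that is a value of about 18%, estimated to fall between 8% and 30%.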

Compound 3, a percentage reported as inhibition, at one concentration (the size of the read-out at that concentration, not a potency): 42.2%
Estimate against measurement, compound 3: 24.2 percentage points below; the measured number lies above the stated range.
By their numbers in this assay, from the lowest: compounds 1 and 2 (each within the scatter of the next); then compound 3.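

The same atoms, joined differently, are enough to change the result at this place: in this assay the rearrangement gives a number 24 percentage points higher from compound 2 to compound 3 (beyond the scatter), although the two groups have the same counts of heavy atoms, hydrogen-bond donors and hydrogen-bond acceptors. Within the data shown here, compound 1 and compound 2 could not be told apart, which made this place look insensitive to what sits on the double-bonded chain carbon, yet the swap of the group from compound 1 for the one in compound 3 gives a number 25.8 percentage points higher from compound 1 to compound 3 (beyond the scatter), so the outcome depends on how the entering group is put together and not only on what it is built from. No separate measurement accompanies these numbers, so nothing here tells why the rearranged group behaves differently.

The compounds shown leave open whether adding a small substituent, such as a methyl group or an amine, to the group in compound 3 would raise or lower the inhibition. Going by these compounds, each number also comes from one concentration, so how potent compound 3 is remains unknown.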